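The source may hold more compounds than are shown below. What is called first, only, known or untested is meant among the compounds shown, and "the series" means these compounds.

Of the compounds shown here, three have been tested in an ADME assay on microsomes from liver (Homo sapiens) for metabolic stability, read by mass spectrometry, using NADPH, with a stated time of 10 min; on this read-out higher numbers stand for a more stable compound and lower numbers for a less stable compound. Compound 1, with the structure `CCCCc1[nH]c(=O)c(-c2nc(Cc3ccccc3)no2)c(O)c1-c1c(OC)cccc1OC`, gives 69%. Compound 2, with the structure `CCOCc1[nH]c(=O)c(-c2nnc(Cc3ccc(Cl)cc3)o2)c(O)c1-c1c(OC)cccc1OC`, gives 94%. Compound 3, with the structure `CCCCc1[nH]c(=O)c(C(=O)OCC)c(O)c1-c1c(OC)cccc1OC`, gives 89%. Compound 2 therefore gives the highest of the three numbers, but the gap to compound 3 lies within the usual scatter of this assay, so the two cannot be told apart on these data; only the gap to compound 1 lies beyond the scatter.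

Compound 4, with the structure `COc1cccc(OC)c1-c1c(C2CC2)[nH]c(=O)c(-c2nnc(Cc3ccc(Cl)cc3)o2)c1O`, has not yet been measured. It differs from compound 2 in one place: cyclopropyl in place of ethoxymethyl on an aromatic carbon

For the measured compounds named here, no step between two measured compounds isolates this kind of change, so the expectation rests on the spread of the three numbers alone. All three measured compounds keep a large share of material after the stated time, and compound 2 starts near the top of the scale. On that basis the change from compound 2 to compound 4 is expected to bring a step of a number 9 percentage points lower from compound 2 to compound 4 (within the scatter), which is none beyond the scatter. For compound 4 the estimate in this assay is 85%, with a range from 65% to 98%.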

Compound 4, percent of the compound remaining: 88%
Compound 4: the middle estimate sits 3 percentage points below what was measured, and the stated range covers the measured number.
By their numbers in this assay, from the lowest: compound 1; then compounds 4, 3 and 2 (each within the scatter of the next).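

For the compounds shown here, compound 2 and compound 4 form the only pair in this assay that differs in one place, so the group on the aromatic carbon next to the ring nitrogen can be judged on its own. Putting cyclopropyl, a three-membered ring of carbon only, in place of ethoxymethyl, an open group that holds an oxygen, brings a step of a number 6 percentage points lower from compound 2 to compound 4 (within the scatter), so this read-out does not tell the two groups apart at this position, at least with the rest of compound 2 held constant. Nothing measured here says what lies behind this result.

The compounds shown leave open how a group of a different kind at this position, such as an amine, a carboxylic acid or a longer chain, would read in this assay. They also leave open whether the same swap would give a similar step in a compound carrying the other groups that compound 1 or compound 3 have elsewhere on the shared core.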